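The source may hold more compounds than are shown below. What is called first, only, known or untested is meant among the compounds shown, and "the series" means these compounds.

In a functional assay on K562 cells (Homo sapiens) for antiproliferative activity, read by MTT assay, with a stated time of 48 h (on this read-out higher numbers stand for weaker inhibition and lower numbers for stronger inhibition), compound 1 `CCN1C(=O)C(=O)c2cc(-c3ccc(OC)cc3)ccc21` gives 2200 nM. Compound 2 `COc1ccc(-c2ccc3c(c2)C(=O)C(=O)N3c2ccc(OC)cc2)cc1` gives > 10000 nM, which is a limit of the assay and not a number. Going by the values given here, compound 3 `COc1ccc(-c2ccc3c(c2)C(=O)C(=O)N3Cc2ccc(F)cc2)cc1` gives 560 nM, the lowest value among the three compounds measured so far. Compound 4 `COc1ccc(-c2ccc3c(c2)C(=O)C(=O)N3Cc2cccc(Cl)c2)cc1` differs from compound 3 by carrying 3-chlorobenzyl instead of 4-fluorobenzyl: 3-chlorophenyl in place of 4-fluorophenyl on a saturated chain carbon bound to an amide-type nitrogen in a ring.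

Three measured steps involve the group at this place on the amide-type nitrogen in a ring. There is a modest 3.9-fold lower number from compound 1 to compound 3 (0.59 log units; beyond the scatter), a large at least 17-fold lower number from compound 2 to compound 3 (1.25 log units; beyond the scatter), and an at least 4.5-fold higher number from compound 1 to compound 2 (0.65 log units; beyond the scatter). These show that this assay responds to changes at this place, but none of them compares two substituted benzyl groups, so they bear on the new change only indirectly. Compound 4 keeps a benzyl group, as compound 3 does at 560 nM, so a shift beyond the scatter is not expected. The estimated change is a 1.3-fold higher number from compound 3 to compound 4 (0.10 log units; within the scatter). For compound 4 the expected value is 700 nM, within an estimated range of 250 nM to 2000 nM.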

Compound 4, half-maximal inhibitory concentration: 200 nM
The estimate for compound 4 lay 3.5-fold (0.54 log units) above the measured number; measured number outside the range, below it.
By their numbers in this assay, from the lowest: compound 4; then compound 3; then compound 1. At a limit, above all of these: compound 2.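

Within this assay, the earlier steps set benzyl groups only against ethyl and 4-methoxyphenyl, while this one compares two substituted benzyl groups and gives a 2.8-fold lower number from compound 3 to compound 4 (0.45 log units; beyond the scatter). The substitution on the benzyl ring therefore moves the number beyond the scatter, and the lead over the ethyl group widens to an 11-fold lower number from compound 1 to compound 4 (1.04 log units; beyond the scatter). Against the 4-methoxyphenyl group the step is an at least 50-fold lower number from compound 2 to compound 4 (1.69 log units; beyond the scatter), and it starts from a limit, not a number: the limit of > 10000 nM in this assay, at which 1 of the 4 values shown sits.

The change from 4-fluorobenzyl to 3-chlorobenzyl alters both the halogen and its location in a single step, so the compounds shown cannot separate the two. From the compounds shown here alone, how 4-chlorobenzyl, 3-fluorobenzyl, unsubstituted benzyl or a longer chain such as 2-phenylethyl would compare on this nitrogen remains open.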